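A few compounds are considered here, and "the series" means these few. Any claim that something is new, unique, unknown or untested is made for them only; others in the source may bear on it.

In a functional assay on A549 cells (Homo sapiens) for antiproliferative activity, read by MTT assay, with a stated time of 48 h (a lower number here means a stronger inhibitor, a higher number a weaker inhibitor), compound 1 (`COC1=CC(=O)N(C(=O)/C=C/[C@H](C)NC(=O)[C@H](CC(C)C)N(C)C)[C@H]1Cc1ccccc1`) gives > 100000 nM, which is a limit of the assay and not a number. Compound 2 (`CC[C@H](C)[C@H](NC(=O)OCc1ccccc1)C(=O)N[C@@H](CC(C)C)C(=O)N[C@@H](CC(C)C)C(=O)N[C@@H](C)/C=C/C(=O)N1C(=O)C=C(OC)[C@@H]1c1cn(C(=O)OC(C)(C)C)c2ccccc12`) gives > 100000 nM, which is also a limit. Going by these compounds, the picture so far is the limit of > 100000 nM in this assay, at which 2 of the 2 values shown sit, so the true strength of compound 2 is unknown.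

Compound 3 (`CC[C@H](C)[C@H](NC(=O)OCc1ccccc1)C(=O)N[C@@H](CC(C)C)C(=O)N[C@@H](CC(C)C)C(=O)N[C@@H](C)/C=C/C(=O)N1C(=O)C=C(OC)[C@@H]1c1c[nH]c2ccccc12`) carries hydrogen in place of tert-butoxycarbonyl on an aromatic nitrogen. Among the compounds with values here, no measured pair shows what this change does, and neither compound tested so far has given a number. Only a modest move toward stronger inhibition is therefore expected, and it may not exceed the usual scatter. The estimated change is an at least 1.6-fold lower number from compound 2 to compound 3 (0.22 log units; that floor lies within the scatter). For compound 3 the expected half-maximal inhibitory concentration is 60000 nM, with an estimated range of 15000 nM to 100000 nM.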

Compound 3, half-maximal inhibitory concentration: > 100000 nM
Compound 3: only a limit was reported (the forecaster's own chance of this, stated with the estimate: 60%); at least 1.6-fold (0.22 log units) between middle value and limit.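

Compound 2 and compound 3 cannot be compared, so no step can be read between them, because their results are limits and not numbers: the limit of > 100000 nM in this assay, at which 3 of the 3 values shown sit.

The compounds shown leave open whether hydrogen in place of tert-butoxycarbonyl on an aromatic nitrogen changes the strength of inhibition at all.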